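Working notes: changing the aryl group of compound 3

The source may report more compounds than this note shows. Statements on the series, on what has been measured and on what is new or still open speak of the compounds shown alone.

- compound 1 `N#Cc1c(-c2ccc(F)cc2)cc(-c2c(O)c3ccccc3oc2=O)nc1N` gives 22300 nM
- compound 2 `COc1cccc(-c2cc(-c3c(O)c4ccccc4oc3=O)nc(O)n2)c1` gives 5550 nM
- compound 3 `O=c1oc2ccccc2c(O)c1-c1cc(-c2ccc(F)cc2)nc(O)n1` gives 2390 nM

All three values come from a functional assay on A549 cells (Homo sapiens) for cytotoxicity, read by MTT assay; a higher number here means a weaker inhibitor, a lower number a stronger inhibitor. Compound 3 has the lowest number of the three, and its gaps to compound 1 and compound 2 both lie beyond the scatter.

Compound 4 `O=c1oc2ccccc2c(O)c1-c1cc(-c2c(F)cccc2Cl)nc(O)n1` has not been measured. It carries 2-chloro-6-fluorophenyl in place of 4-fluorophenyl on an aromatic carbon.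

Within the data shown here, only one measured step bears directly on this change: a 2.3-fold lower number from compound 2 to compound 3 (0.37 log units; beyond the scatter). It is modest and involves an aryl exchange at the same place. Among the measured compounds shown here, compound 1 is joined to the others by no single-place step, so it gives no size to carry over. For the measured compounds named here, no measured compound carries a 2-chloro-6-fluorophenyl group, which leaves the direction poorly fixed.

A step of modest size at most is expected in this assay. With compound 3 at 2390 nM already the lowest of the three, a slight lean toward a higher number is expected. The expected step is a 1.5-fold higher number from compound 3 to compound 4 (0.17 log units; within the scatter). The estimate for compound 4 is 3500 nM, with an expected range from 1200 nM to 10000 nM.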

Compound 4, half-maximal inhibitory concentration: 5100 nM
The estimate for compound 4 lay 1.5-fold (0.16 log units) below the measured number; the measured number falls inside the stated range.
By their numbers in this assay, from the lowest: compound 3; then compounds 4 and 2 (each within the scatter of the next); then compound 1.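

In this assay, 2-chloro-6-fluorophenyl on this aromatic carbon of the shared core gives a 2.1-fold higher number from compound 3 to compound 4 (0.33 log units; beyond the scatter) and so adds a second modest step away from 4-fluorophenyl, which now holds the lowest number against two other aryl groups at the same place. Set against 3-methoxyphenyl, the same group gives a 1.1-fold lower number from compound 2 to compound 4 (0.04 log units; within the scatter) and leaves those two compounds indistinguishable in this assay, so the three aryl groups fall into two levels, with only compound 3 standing apart. No measurement on hand explains this difference between the aryl groups.

The chlorine and fluorine enter together in compound 4, so the compounds shown do not separate what each contributes, and 2-chlorophenyl and 2-fluorophenyl would be the direct comparisons. All groups shown at this place are substituted phenyl rings, which leaves open how an unsubstituted phenyl, a pyridine, an amine or a carboxylic acid would compare on the same carbon.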